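The source may hold more compounds than are shown below. What is called first, only, known or untested is meant among the compounds shown, and "the series" means these compounds.

In an ADME assay on L02 cells (Homo sapiens) for cytotoxicity, read by MTT assay, with a stated time of 48 h (on this read-out higher numbers stand for weaker inhibition and lower numbers for stronger inhibition), compound 1 `CCN1CCN(C[C@H]2CN(c3ccc(-n4cc(-c5ccccn5)cn4)c(F)c3)C(=O)O2)CC1` gives 99 ug/mL and compound 3 `O=C1O[C@@H](Cn2ccnn2)CN1c1ccc(-n2cc(-c3ccccn3)cn2)c(F)c1` gives 49 ug/mL. Compound 2 `COC(=O)CC1CCN(C[C@H]2CN(c3ccc(-n4cc(-c5ccccn5)cn4)c(F)c3)C(=O)O2)CC1` reaches only a limit, > 400 ug/mL.

Of the two numbers, compound 3 stands lowest, with compound 1 nearest above it, as the step of a 2.0-fold lower number from compound 1 to compound 3 (0.31 log units; beyond the scatter) shows. Compound 4 `NC(=O)[C@H]1CN(c2ccc(-n3cc(-c4ccccn4)cn3)c(F)c2)C(=O)O1` differs from compound 3 in one place: carbamoyl in place of (1H-1,2,3-triazol-1-yl)methyl on a saturated ring carbon. All measured steps alter the group on a saturated chain carbon bound to a saturated ring carbon: a 2.0-fold lower number from compound 1 to compound 3 (0.31 log units; beyond the scatter), an at least 8.1-fold lower number from compound 2 to compound 3 (0.91 log units; beyond the scatter) and an at least 4.0-fold higher number from compound 1 to compound 2 (0.60 log units; beyond the scatter). None introduces carbamoyl, so they show only that this part of the molecule moves the number by modest amounts. The step to compound 4 is therefore expected to be small and upward, a 1.6-fold higher number from compound 3 to compound 4 (0.21 log units; within the scatter). Compound 4 is estimated at 80 ug/mL, between 30 ug/mL and 250 ug/mL.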

Compound 4, half-maximal inhibitory concentration: 119 ug/mL
The estimate for compound 4 lay 1.5-fold (0.17 log units) below the measured number; the range from low to high includes it.
By their numbers in this assay, from the lowest: compound 3; then compounds 1 and 4 (each within the scatter of the next). At a limit, above all of these: compound 2.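

On the saturated ring carbon next to the ring oxygen, carbamoyl in place of (1H-1,2,3-triazol-1-yl)methyl gives a 2.4-fold higher number from compound 3 to compound 4 (0.39 log units; beyond the scatter) in this assay and shows that a change made on the ring carbon itself, with no ring in the entering group, can move the number beyond the scatter. Carbamoyl and (4-ethylpiperazin-1-yl)methyl cannot be told apart here, with a 1.2-fold higher number from compound 1 to compound 4 (0.08 log units; within the scatter) as their step. The third step, an at least 3.3-fold lower number from compound 2 to compound 4 (0.52 log units; beyond the scatter), rests on a limit of the assay: the limit of > 400 ug/mL in this assay, at which 1 of the 4 values shown sits.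

The compounds shown leave open whether a carboxylic acid, an amine or a longer chain ending in carbamoyl on this ring carbon would give a number that differs from that of compound 4.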